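The source may hold more compounds than are shown below. What is called first, only, known or untested is meant among the compounds shown, and "the series" means these compounds.

Of the compounds shown here, two built on a shared core have been measured so far in a functional assay on HepG2 cells (Homo sapiens) for antiproliferative activity, read by MTT assay, with a stated time of 72 h; on this read-out higher numbers stand for weaker inhibition and lower numbers for stronger inhibition. Compound 1 (`O=C(N/N=C/c1ccc(Br)cc1)Nc1ccc(Oc2ccnc3[nH]ccc23)c(F)c1`) gives 1000 nM. Compound 2 (`O=C(N/N=C/c1ccc(O)cc1O)Nc1ccc(Oc2ccnc3[nH]ccc23)c(F)c1`) gives 4550 nM, the higher of the two numbers and so the weaker inhibition of the pair.

The next compound is compound 3 (`O=C(N/N=C/c1cc(Br)c(O)c(Br)c1)Nc1ccc(Oc2ccnc3[nH]ccc23)c(F)c1`), which has 3,5-dibromo-4-hydroxyphenyl in place of 2,4-dihydroxyphenyl on a carbon with a double bond to nitrogen.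

Going by the values given here, only one measured step bears on this change: a 4.6-fold higher number from compound 1 to compound 2 (0.66 log units; beyond the scatter). In that modest step, a 2,4-dihydroxyphenyl group replaced a phenyl group carrying bromine. The group entering compound 3 resembles both earlier groups, with bromine as in compound 1 and a hydroxy group as in compound 2. Among the compounds with values here, the new change therefore partly reverses the measured step, but a single step is thin evidence, and no measured compound shows this exact group.

A step of similar or smaller size is expected, toward a lower number. The expected change is a 3.0-fold lower number from compound 2 to compound 3 (0.48 log units; beyond the scatter). The estimated value for compound 3 is 1500 nM, with an expected range from 500 nM to 4500 nM.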

Compound 3, half-maximal inhibitory concentration: 6520 nM
The estimate for compound 3 lay 4.3-fold (0.64 log units) below the measured number; the whole stated range lies below it.
By their numbers in this assay, from the lowest: compound 1; then compounds 2 and 3 (each within the scatter of the next).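

In this assay, the change on the carbon with a double bond to nitrogen gives a 1.4-fold higher number from compound 2 to compound 3 (0.16 log units; within the scatter), so these two quite different rings, 2,4-dihydroxyphenyl and 3,5-dibromo-4-hydroxyphenyl, cannot be told apart at this position, even though one carries two bromines and the other a second hydroxy group. Bromine on the ring therefore does not by itself bring back the lower number seen with 4-bromophenyl, as the comparison with that ring gives a 6.5-fold higher number from compound 1 to compound 3 (0.81 log units; beyond the scatter). Among these three compounds, the only ring without a hydroxy group gives the lowest number and no compound goes against that, but three compounds make a thin pattern, and nothing available explains how these numbers arise.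

As far as these compounds go, what remains open is whether a hydroxy group alone goes with the higher numbers, a question that 4-hydroxyphenyl or plain phenyl at this position could help to answer. From the compounds shown here alone, it is also open how this position responds to quite different groups, such as a phenyl ring carrying an amine or a carboxylic acid.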